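A few compounds are considered here, and "the series" means these few. Any claim that something is new, unique, unknown or untested is made for them only; others in the source may bear on it.

Series in an assay (Cricetulus griseus) for inhibition of aldehyde dehydrogenase, mitochondrial (Homo sapiens); a lower number here means a stronger inhibitor, a higher number a weaker inhibitor:
compound 1 `NCCCCCCOc1ccc2c(=O)c(-c3ccc(O)cc3)coc2c1` gives 100 nM
compound 2 `O=c1c(-c2ccc(O)cc2)coc2cc(OCCCCCCCCCO)ccc12` gives 700 nM
compound 3 `O=C(O)CCCCCCOc1ccc2c(=O)c(-c3ccc(O)cc3)coc2c1` gives 50 nM

Compound 3 holds the lowest number of the three; its gap to compound 1 lies within the scatter, so no order between those two is claimed, while a 14-fold lower number from compound 2 to compound 3 (1.15 log units; beyond the scatter) is large. Compound 4 `O=C(O)CCCCOc1ccc2c(=O)c(-c3ccc(O)cc3)coc2c1` differs from compound 3 by carboxy in place of 2-carboxyethyl on a saturated chain carbon, four bonds along the chain from an oxygen on an aromatic ring. Among the measured compounds shown here, no measured step shortens the chain while keeping the terminal group, so the guide is indirect: every change so far sits at the chain end, with a 2.0-fold lower number from compound 1 to compound 3 (0.30 log units; within the scatter) small and a 7.0-fold higher number from compound 1 to compound 2 (0.85 log units; beyond the scatter) modest. With the carboxy retained and only the chain shortened, a step within the scatter in this assay is expected, if anything toward a higher number. For compound 4 the expected value is 90 nM, range 30 nM to 300 nM. This corresponds to an expected step of a 1.8-fold higher number from compound 3 to compound 4 (0.26 log units; within the scatter).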

Compound 4, half-maximal inhibitory concentration: 100 nM
For compound 4 the middle estimate is 1.1-fold (0.05 log units) below the measured one; measured number inside the range.
By their numbers in this assay, from the lowest: compounds 3, 1 and 4 (each within the scatter of the next); then compound 2.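

In this assay, among the compounds shown here, shortening the carboxy-ended chain gives a 2.0-fold higher number from compound 3 to compound 4 (0.30 log units; within the scatter) and is the first change here that keeps the terminal carboxy, so this read-out does not separate these two chain lengths. Against the amine-ended chain there is no change at the digits printed from compound 1 to compound 4 (within the scatter) while the long hydroxy-ended chain differs by a 7.0-fold lower number from compound 2 to compound 4 (0.85 log units; beyond the scatter) so the shorter acid stays within reach of the other active compounds. No supporting measurement bears on the reason for these steps.
Still open, on these data alone, are a methyl ester at the chain end and an amine or hydroxy group on the shorter chain of compound 4. A carboxymethyl chain would test whether further shortening stays as flat.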